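A Chloro Step Against the Assay Floor

The compounds below may be only part of what the source reports. "The series", "measured", "known", "first", "only" and "open" are said of these compounds alone.

compound 1 `COc1cc(/C=C2\C(=O)Nc3ccccc32)ccc1OCCCN1CCN(c2ccccn2)CC1`: > 20000 nM
compound 2 `COc1cc(/C=C2\C(=O)Nc3ccc(Cl)cc32)ccc1OCCCN1CCN(c2ccccn2)CC1`: 14800 nM
compound 3 `COc1cc(/C=C2\C(=O)Nc3ccccc32)ccc1OCCCN1CCN(c2ncccc2C(F)(F)F)CC1`: > 20000 nM

In a functional assay on MDA-MB-231 cells (Homo sapiens) for cytotoxicity, read by MTT assay, with a stated time of 48 h (on this read-out higher numbers stand for weaker inhibition and lower numbers for stronger inhibition), compound 3 gives only a limit, > 20000 nM, and no number. Compound 4 `COc1cc(/C=C2\C(=O)Nc3ccc(Cl)cc32)ccc1OCCCN1CCN(c2ncccc2C(F)(F)F)CC1` differs from compound 3 by chloro in place of hydrogen on an aromatic carbon. Going by the values given here, the one measured step with the same change is an at least 1.3-fold lower number from compound 1 to compound 2 (0.13 log units; that floor lies within the scatter), and it too starts from a limit, so only its floor is known, and that floor lies within the scatter. The starting points here are shaped by the limit of > 20000 nM in this assay, at which 2 of the 3 values shown sit. For compound 4 in this assay a step no larger than the scatter is therefore expected, if anything toward a lower number, with a fair chance that only a limit is reported again. Compound 4 is expected near 18000 nM, within 7000 nM to 45000 nM. That would mean an expected step of an at least 1.1-fold lower number from compound 3 to compound 4 (0.04 log units; that floor lies within the scatter).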

Compound 4, half-maximal inhibitory concentration: 1260 nM
Compound 4: the middle estimate sits 14-fold (1.15 log units) above what was measured, and the stated range ends above it.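

In this assay, chloro on this aromatic carbon can carry a large step, an at least 15-fold lower number from compound 3 to compound 4 (1.20 log units; beyond the scatter), which the earlier pair, with its floor inside the scatter, did not show. Trifluoromethyl, whose step without chloro cannot be read, also gives a large step with chloro present, a 12-fold lower number from compound 2 to compound 4 (1.07 log units; beyond the scatter). Among the compounds shown, only the one holding both groups falls this far.

As far as these compounds go, whether chloro acts more strongly on the trifluoromethyl core than on the core of compound 1 stays open: the same change on two cores in this assay, an at least 1.3-fold lower number (0.13 log units; that floor lies within the scatter) from compound 1 to compound 2 and an at least 15-fold lower number (1.20 log units; beyond the scatter) from compound 3 to compound 4; the limit leaves it open whether they differ Whether bromo or methoxy on this aromatic carbon would match chloro also remains open.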